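A few compounds are considered here, and "the series" means these few. Any claim that something is new, unique, unknown or untested is made for them only; others in the source may bear on it.

Measured in a functional assay on A549 cells (Homo sapiens) for antiproliferative activity, read by MTT assay, with a stated time of 72 h; on this read-out lower numbers stand for stronger inhibition and higher numbers for weaker inhibition:
compound 1 `Cc1noc(C)c1-c1nn(Cc2ccc(C(=O)N3CCCCC3)cc2)c(=O)c2ccccc12`: 86200 nM
compound 2 `Cn1cc(-c2nn(Cc3ccc(C(=O)NC4CC(C)(C)N([O])C(C)(C)C4)cc3)c(=O)c3ccccc23)cn1`: 37300 nM
compound 3 `CC(=O)Nc1ccc(Sc2nc(Nc3cc(C)[nH]n3)cc(N3CCN(C)CC3)n2)cc1`: 15300 nM

Compound 1 has the highest number of the three. Compound 2 lies nearest to it and compound 3 furthest, and both gaps are beyond the usual scatter. All three values sit in a weak range, so compound 1 is a low starting point within a small set.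

The next compound is compound 4 `Cc1noc(C)c1-c1nn(Cc2ccc(C(=O)NC3CCCC3)cc2)c(=O)c2ccccc12`, which has the same atoms as compound 1, joined differently: cyclopentylamino in place of piperidin-1-yl on a carbonyl carbon. In words, cyclopentylamino stands in place of piperidin-1-yl on a carbonyl carbon, and the rest of the molecule is unchanged.

Among the compounds with values here, no two measured compounds differ in only one place, so this assay offers no direct precedent for this change. Within the data shown here, the only indirect hint is compound 2, which also has a ring on an amino group at the carbonyl carbon and gives 37300 nM. It differs from compound 1 elsewhere too, so this support is weak.

The expected step is a 1.7-fold lower number from compound 1 to compound 4 (0.24 log units; within the scatter), toward a lower number and not clearly beyond the scatter. Compound 4 is estimated at 50000 nM, with an expected range of 20000 nM to 110000 nM.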

Compound 4, half-maximal inhibitory concentration: > 100000 nM
Compound 4 gave a limit, no number; the forecaster's own chance of this, stated with the estimate: 20%; middle value at least 2.0-fold (0.30 log units) away from the limit.
By their numbers in this assay, from the lowest: compound 3; then compound 2; then compound 1. At a limit, above all of these: compound 4.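

In this assay compound 4 gives > 100000 nM, which is a limit of the assay and not a number. Read as a step, the change is an at least 1.1-fold higher number from compound 1 to compound 4 (0.06 log units; that floor lies within the scatter), so at this carbonyl carbon, where the earlier compounds offered no step at all, cyclopentylamino in place of piperidin-1-yl brings no lowering of the number, even with 1 hydrogen-bond donor entering where piperidin-1-yl has 0. The floor alone does not separate compound 4 from compound 1, and only a bound is fixed for this change, not its size: the limit of > 100000 nM in this assay, at which 1 of the 4 values shown sits.

The swap alters the ring, five-membered of carbon only against six-membered with 1 hetero atom, and brings in the amide hydrogen at the same time, so the compounds shown do not tell these two differences apart. Open, going by these compounds, is how pyrrolidin-1-yl, which keeps the five-membered ring without the amide hydrogen, and cyclohexylamino, which keeps the amide hydrogen on a six-membered ring, would read on that carbonyl carbon in this assay.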